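A few compounds are considered here, and "the series" means these few. Any claim that something is new, unique, unknown or untested is made for them only; others in the source may bear on it.

In a functional assay on HT cells (Homo sapiens) for antiproliferative activity, read by fluorescence, with a stated time of 72 h (a higher number here means a weaker inhibitor of growth, a lower number a stronger inhibitor of growth), compound 2 `CC(C)c1n[nH]c2c(NCc3ccc(-c4ccccn4)cc3)nc(SCCNC(N)=O)nc12` gives 240 nM and compound 1 `CC(C)c1n[nH]c2c(NCc3ccc(-c4ccccn4)cc3)nc(SCCNC(=N)N)nc12` gives 390 nM, so the two cannot be told apart. Compound 3 `CC(C)c1n[nH]c2c(NCc3ccc(-c4ccccn4)cc3)nc(SC[C@H](O)CN)nc12`, not yet measured, carries 2-amino-1-hydroxyethyl in place of ureidomethyl on a saturated chain carbon bound to a sulfur. Among the measured compounds shown here, the one measured step that bears on this, a 1.6-fold lower number from compound 1 to compound 2 (0.21 log units; within the scatter), also exchanged a small group without a ring and stayed within the scatter. One step is thin evidence, but it gives no reason to expect more here. The expected step is a 1.3-fold higher number from compound 2 to compound 3 (0.10 log units; within the scatter), which is no larger than the scatter. Compound 3 is estimated at 300 nM, within a range of 100 nM to 900 nM.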

Compound 3, concentration for 50% growth inhibition: 63 nM
Estimate against measurement, compound 3: 4.8-fold (0.68 log units) above; the whole stated range lies above it.
By their numbers in this assay, from the lowest: compound 3; then compounds 2 and 1 (each within the scatter of the next).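

In this assay, this position proved able to move the number beyond the scatter, which the earlier exchange on the same chain had not shown. Putting 3-amino-2-hydroxypropyl in place of 2-ureidoethyl gives a 3.8-fold lower number from compound 2 to compound 3 (0.58 log units; beyond the scatter), and the same group set against the nitrogen-richer chain gives a 6.2-fold lower number from compound 1 to compound 3 (0.79 log units; beyond the scatter). No measurement offered here explains these steps.

Going by these compounds, it remains open whether the amine, the hydroxyl or the defined stereocentre carries the gain. A plain 2-aminoethyl chain, the opposite stereocentre and a carboxylic acid at this place would help separate these.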